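Replacing the thiazole arm of compound 2 with a fluorinated oxazole

The source may report more compounds than this note shows. Statements on the series, on what has been measured and on what is new or still open speak of the compounds shown alone.

Measured compounds:
- compound 1, `Cc1ccc(NC(=O)CC(CCC(=O)N(C)C)c2nnc(CCCC(C)C)n2C2CC2)c(C)c1`: 45%
- compound 2, `Cc1ccc(NC(=O)C[C@H](CCC(=O)O)c2noc(-c3ncc(CC(C)C)s3)c2C2CC2)c(Cl)c1`: 82%
- compound 3, `CC(C)(C)Cc1cc(-c2onc([C@@H](CCC(=O)O)CC(=O)Nc3ccc(Cl)cc3Cl)c2C2CC2)no1`: 96%

In an ADME assay on microsomes from liver (Homo sapiens) for metabolic stability, with a stated time of 60 min (a higher number here means that more of the compound is left, a lower number that less of the compound is left), compound 2 gives 82%, the second highest of the three numbers. Its nearest neighbour is compound 3, whose 96% lies higher by more than the usual scatter, while compound 1, with 45%, sits far below it. Within the data shown here, no pair of these measured compounds differs in only one place, so no single step can be read from them.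

Compound 4, `Cc1ccc(NC(=O)C[C@H](CCC(=O)O)c2noc(-c3cc(C(F)(F)C(C)(C)C)on3)c2C2CC2)c(Cl)c1`, has not been measured yet. It differs from compound 2 in one place: 5-(1,1-difluoro-2,2-dimethylpropyl)-1,2-oxazol-3-yl in place of 5-isobutyl-1,3-thiazol-2-yl on an aromatic carbon. Because compound 2 already gives 82%, the expected step from compound 2 to compound 4 is a number 3 percentage points higher from compound 2 to compound 4 (within the scatter), a small rise that may well stay within the usual scatter. Compound 4 is therefore estimated to give 85%, with a plausible range from 65% to 97%.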

Compound 4, percent of the compound remaining: 77%
Compound 4: the middle estimate sits 8 percentage points above what was measured; measured number inside the range.
By their numbers in this assay, from the lowest: compound 1; then compounds 4 and 2 (each within the scatter of the next); then compound 3.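

In this assay this position accepts a swap of the whole arm with no readable effect, with a number 5 percentage points lower from compound 2 to compound 4 (within the scatter) when 5-(1,1-difluoro-2,2-dimethylpropyl)-1,2-oxazol-3-yl takes the place of 5-isobutyl-1,3-thiazol-2-yl. The sulfur-containing ring is therefore not required for a high number here, and an arm of 12 heavy atoms, two of them fluorine, serves as well as one of 9. Nothing available explains why the two compounds stand so close.

Ring and chain change together in this step, so the part played by each, and by the two fluorine atoms, remains unresolved. The compounds shown also leave open how this position would respond to an arm carrying an amine.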